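Replacing the 2,4-dichlorophenyl group of compound 1

This account rests on a few compounds, and the source may have more. Where it says the series, first, only, none or still open, it means among the compounds named here.

Measured in a functional assay on DU-145 cells (Homo sapiens) for inhibition, read by trypan blue exclusion, with a stated time of 96 h; on this read-out lower numbers stand for stronger inhibition of growth and higher numbers for weaker inhibition of growth:
- Compound 1 `O=C(/C(=C\c1ccc(Cl)cc1Cl)S(=O)(=O)c1ccc(Br)cc1)c1ccc(Cl)cc1`: 50000 nM
- Compound 2 `O=C(/C(=C\c1ccccc1OCc1ccccc1)SCc1ccc(F)cc1)c1ccc(Cl)cc1`: 1000 nM
- Compound 3 `Cc1cc(C)cc(/C=C(\C(=O)c2ccc(Br)cc2)S(=O)(=O)Cc2ccc(F)cc2)c1`: 10000 nM

Compound 1 stands highest of the three at 50000 nM, which makes it the weakest growth inhibitor among them. Compound 3 at 10000 nM and compound 2 at 1000 nM both lie beyond the usual scatter from it.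

Compound 4 `O=C(/C(=C\c1ccccc1F)S(=O)(=O)c1ccc(Br)cc1)c1ccc(Cl)cc1` has not yet been measured. It keeps the core of compound 1 but carries 2-fluorophenyl in place of 2,4-dichlorophenyl on a double-bonded chain carbon bound to a double-bonded chain carbon. Among the compounds with values here, no pair of measured compounds shows this change alone, so its effect can only be judged loosely. Compound 1 at 50000 nM has the other measured values beneath it, so a move toward lower numbers seems the likelier direction. The step expected in this assay is moderate, an estimated 3.3-fold lower number from compound 1 to compound 4 (0.52 log units; beyond the scatter). Compound 4 is estimated at 15000 nM, with an expected range from 3000 nM to 60000 nM.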

Compound 4, concentration for 50% growth inhibition: 25000 nM
Beside the measured number, compound 4's estimate is 1.7-fold (0.22 log units) below it; low and high end bracket the measured number.
By their numbers in this assay, from the lowest: compound 2; then compound 3; then compounds 4 and 1 (each within the scatter of the next).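

In this assay, this position now has its first direct reading: replacing 2,4-dichlorophenyl with 2-fluorophenyl gives a 2.0-fold lower number from compound 1 to compound 4 (0.30 log units; within the scatter). With the rest of the core of compound 1 held fixed, this exchange therefore cannot be told apart from repeat measurement, even though the entering group has one fewer heavy atom and fluorine stands in place of both chlorines. No measurement shown here offers an explanation for this outcome.

The compounds shown leave open whether an amine or a carboxylic acid on this phenyl ring would give a step beyond the scatter. They also leave open whether the same exchange would give a similar step in a compound carrying the benzyl thioether of compound 2 in place of the sulfonyl-linked bromophenyl group.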